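Swapping one side chain: what happens to clearance?

The compounds below may be only part of what the source reports. "The series", "measured", "known", "first", "only" and "open" are said of these compounds alone.

In an ADME assay on the whole organism (strain CD) for pharmacokinetics, with Rattus norvegicus as the target, at a dose of 1 mg/kg (a lower number here means slower removal, a higher number faster removal of the compound), compound 1 (`CC(=O)NCc1cccc(Cn2nc(NS(=O)(=O)c3ccc(Cl)s3)c3c(O)cccc32)c1`) gives 19 mL/min/kg and compound 2 (`CN[C@H](C)C(=O)NCc1cccc(Cn2nc(NS(=O)(=O)c3ccc(Cl)s3)c3c(OC)cccc32)c1`) gives 17 mL/min/kg as its reading. These two numbers lie within the usual scatter of each other, so they show no real difference. Compound 3 (`COc1cccc2c1c(NS(=O)(=O)c1ccc(Cl)s1)nn2Cc1cccc(CNC(=O)[C@@H]2CCCCN2)c1`) has not yet been measured. It differs from compound 2 in one place, on a carbonyl carbon, where piperidin-2-yl takes the place of 1-(methylamino)ethyl (piperidin-2-yl in place of 1-(methylamino)ethyl on a carbonyl carbon). Among the compounds with values here, no measured pair in this small set differs in one place only, so nothing shows directly how such a swap moves the number. Compound 2 at 17 mL/min/kg as its reading is the closest guide. The estimated step of a 1.2-fold higher number from compound 2 to compound 3 (0.07 log units; within the scatter) is expected to stay within the scatter, with no firm direction. Compound 3 is estimated at 20 mL/min/kg in this assay with 10 mL/min/kg to 40 mL/min/kg as the likely range.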

Compound 3, clearance: 29 mL/min/kg
Beside the measured number, compound 3's estimate is 1.5-fold (0.16 log units) below it; measured number inside the range.
By their numbers in this assay, from the lowest: compounds 2, 1 and 3 (each within the scatter of the next).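

Within the data shown here, compound 2 and compound 3 give the first comparison here that isolates a single change. In this assay, piperidin-2-yl in place of 1-(methylamino)ethyl on a carbonyl carbon gives a 1.7-fold higher number from compound 2 to compound 3 (0.23 log units; within the scatter), so adding a six-membered non-aromatic ring at this position, with the counts of hydrogen-bond donors and acceptors unchanged, produces no real difference in clearance. Nothing available bears on the reason for this result.

This single swap cannot show how far the position tolerates change, and compound 1 differs from compound 2 and compound 3 in more than one place, so it offers no clean comparison. Going by these compounds, it remains open whether a pyrrolidin-2-yl ring, a longer chain or a carboxylic acid on this carbonyl carbon would shift clearance beyond the usual scatter.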